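Hydroxy-dimethylphenyl isomers in the KB antiproliferative series

The source may hold more compounds than are shown below. What is called first, only, known or untested is meant among the compounds shown, and "the series" means these compounds.

Measured in a functional assay on KB cells (Homo sapiens) for antiproliferative activity, read by sulforhodamine B assay, with a stated time of 3 days; a lower number here means that less compound is needed, a higher number that more compound is needed for the effect:
- compound 1 `CCC1=C(O)c2c(oc(-c3cccc(C)c3)cc2=O)C(CC)(CC)C1=O` 49.7 uM
- compound 2 `CCC1=C(O)c2c(oc(-c3ccccc3F)cc2=O)C(CC)(CC)C1=O` > 56.2 uM (a limit of the assay, not a number)
- compound 3 `CCC1=C(O)c2c(oc(-c3ccc(O)c(C)c3C)cc2=O)C(CC)(CC)C1=O` 6.5 uM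

Compound 3 has the lower of the two true numbers, with a 7.6-fold lower number from compound 1 to compound 3 (0.88 log units; beyond the scatter). Compound 2 reads only as a limit, and an at least 8.6-fold lower number from compound 2 to compound 3 (0.93 log units; beyond the scatter).

Next comes compound 4 `CCC1=C(O)c2c(oc(-c3cc(C)c(O)c(C)c3)cc2=O)C(CC)(CC)C1=O`, an isomer of compound 3: 4-hydroxy-3,5-dimethylphenyl in place of 4-hydroxy-2,3-dimethylphenyl on an aromatic carbon. Here 4-hydroxy-3,5-dimethylphenyl replaces 4-hydroxy-2,3-dimethylphenyl on an aromatic carbon, next to the ring oxygen. The two steps into compound 3 both exchange a different group for the 4-hydroxy-2,3-dimethylphenyl, so they bear on this change only indirectly. Among the measured compounds shown here, no measured step moves a methyl group while keeping the hydroxy group. For the measured compounds named here, compound 4 keeps the same atoms in the group, so it is expected to stay close to compound 3 in this assay, with no step clearly beyond the scatter. The expected change is a 1.2-fold higher number from compound 3 to compound 4 (0.09 log units; within the scatter). For compound 4 the estimated value is 8 uM, within an expected range of 2.5 uM to 30 uM.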

Compound 4, concentration for half-maximal effect: 18.3 uM
For compound 4 the middle estimate is 2.3-fold (0.36 log units) below the measured one, and the stated range covers the measured number.
By their numbers in this assay, from the lowest: compound 3; then compound 4; then compound 1. At a limit, above all of these: compound 2.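

In this assay, 4-hydroxy-3,5-dimethylphenyl in place of 4-hydroxy-2,3-dimethylphenyl gives a 2.8-fold higher number from compound 3 to compound 4 (0.45 log units; beyond the scatter), so the arrangement of the methyl groups alone changes the read-out at this carbon, with the atoms of the group unchanged. The 4-hydroxy-3,5-dimethylphenyl group still gives a 2.7-fold lower number from compound 1 to compound 4 (0.43 log units; beyond the scatter) and an at least 3.0-fold lower number from compound 2 to compound 4 (0.48 log units; beyond the scatter), so both hydroxy-dimethylphenyl isomers read lower than the groups without a hydroxy group shown here. Compound 2 stands only as a limit of the assay: the limit of > 56.2 uM in this assay, at which 1 of the 4 values shown sits.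

As far as these compounds go, how much of the lower numbers belongs to the hydroxy group and how much to the methyl groups remains open. A methoxy group or an amine in place of the hydroxy group, on the same dimethylphenyl frame, would separate the two.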